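Two Fluorines Relocated: From Compound 3 to Compound 4

This account rests on a few compounds, and the source may have more. Where it says the series, first, only, none or still open, it means among the compounds named here.

Compound 1 `O=C(c1ccccc1)N1CCc2nc(COc3cccc(F)c3)oc2C1`: 73%
Compound 2 `O=C(c1cccc(F)c1)N1CCc2nc(COc3cccc(F)c3)oc2C1`: 75%
Compound 3 `O=C(c1cc(F)cc(F)c1)N1CCc2nc(COc3cccc(F)c3)oc2C1`: 42%

In a functional assay on HEK293 cells for positive allosteric modulation of metabotropic glutamate receptor 5 (Homo sapiens), read by calcium flux (on this read-out lower numbers stand for smaller maximal responses and higher numbers for larger maximal responses), compound 3 gives the lowest of the three numbers. Its nearest neighbour is compound 1, which in this assay gives 73%; the step of a number 31 percentage points lower from compound 1 to compound 3 (beyond the scatter) is large and beyond the scatter. Compound 2, which gives 75%, lies furthest away, and the step of a number 33 percentage points lower from compound 2 to compound 3 (beyond the scatter) is likewise large. By contrast the step of a number 2 percentage points higher from compound 1 to compound 2 (within the scatter) lies within the scatter, so one fluorine on that ring changed little, while the second, giving the 3,5-difluorophenyl, brought the large fall.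

Compound 4 `O=C(c1c(F)cccc1F)N1CCc2nc(COc3cccc(F)c3)oc2C1` differs from compound 3 in one place: 2,6-difluorophenyl in place of 3,5-difluorophenyl on a carbonyl carbon. For the measured compounds named here, no measured step exchanges one difluorophenyl for another, so none bears directly on this change. The measured steps only show that the 3,5-difluorophenyl goes with the lower response, and say nothing about the 2,6-difluorophenyl. The direction is therefore open; an estimate of a moderate rise with a wide range seems fair, since compound 3 already stands at 42% and the others sit higher. Compound 4 is expected to give 58%, between 30% and 85%. The estimated step of a number 16 percentage points higher from compound 3 to compound 4 (beyond the scatter) is thus uncertain and could fall within the scatter.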

Compound 4, largest response reached (reported as percent of maximum), in percent of the reference or control that the assay uses: 82%
Estimate against measurement, compound 4: 24 percentage points below; measured number inside the range.
By their numbers in this assay, from the lowest: compound 3; then compounds 1, 2 and 4 (each within the scatter of the next).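

In this assay, moving the same two fluorines to give the 2,6-difluorophenyl in place of the 3,5-difluorophenyl on the carbonyl carbon gives a number 40 percentage points higher from compound 3 to compound 4 (beyond the scatter), so the fall seen with compound 3 goes with where the fluorines stand on this ring, not with the presence of a second fluorine as such. For the compounds shown here, the two fluorines of compound 4 also cost nothing measurable against the 3-fluorophenyl or the plain phenyl, with readings of a number 7 percentage points higher from compound 2 to compound 4 (within the scatter) and a number 9 percentage points higher from compound 1 to compound 4 (within the scatter), which leaves the 3,5-difluorophenyl as the only one of the four rings that stands apart at this position. Nothing at hand gives a reason why the placement of the fluorines matters so much here.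

Whether this tolerance belongs to fluorine alone stays open, since the compounds shown do not tell how the response would go with chloro or methyl groups in place of the two fluorines of the 2,6-difluorophenyl. Nor do they show whether a pyridine ring on the carbonyl carbon would keep the response of the phenyl rings or lose it as compound 3 does.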